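The source may report more compounds than this note shows. Statements on the series, on what has been measured and on what is new or still open speak of the compounds shown alone.

Measured in an ADME assay on CCRF-CEM cells (Homo sapiens) for cytotoxicity, with a stated time of 3 days; a lower number here means that less compound is tolerated, a higher number that more compound is tolerated:
- Compound 1 `Cc1ccc(Cn2c(=O)cc(C)n(C3C=CC(OC(=O)c4ccccc4)C3)c2=O)cc1`: 20000 nM
- Compound 2 `Cc1ccc(Cn2c(=O)ccn(C3C=CC(OC(=O)c4ccccc4)C3)c2=O)cc1`: > 25000 nM, a limit of the assay and not a number

Compound 2 therefore has no exact position on the numbers, only a limit: the limit of > 25000 nM in this assay, at which 1 of the 2 values shown sits. Compound 3 `Cc1cc(C)cc(Cn2c(=O)ccn(C3C=CC(OC(=O)c4ccccc4)C3)c2=O)c1` keeps the shared core and differs from it at one place, with 3,5-dimethylphenyl in place of 4-methylphenyl on a saturated chain carbon bound to an aromatic nitrogen. Going by the values given here, only one measured step is available, an at least 1.2-fold higher number from compound 1 to compound 2 (0.09 log units; that floor lies within the scatter). It concerns a different change, hydrogen in place of methyl on an aromatic carbon, so it bears on this one only indirectly, and its floor lies within the scatter. No step beyond the scatter is therefore expected in this assay, in either direction. For compound 3 the expected value is 23000 nM, with an estimated range of 11000 nM to 40000 nM. This estimate means an expected at least 1.0-fold lower number from compound 2 to compound 3 (0.03 log units; that floor lies within the scatter).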

Compound 3, half-maximal cytotoxic concentration: 40000 nM
The estimate for compound 3 lay 1.7-fold (0.24 log units) below the measured number; the range from low to high includes it.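

Compound 2 carries only a limit and not a number, so no step from it to compound 3 can be read in this assay: the limit of > 25000 nM in this assay, at which 1 of the 3 values shown sits.

The compounds shown leave open whether 3,5-dimethylphenyl in place of 4-methylphenyl changes the number in this assay at all, and in which direction.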